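Hydroxy substitution on an aryl hydrazone series

The compounds below may be only part of what the source reports. "The series", "measured", "known", "first", "only" and "open" are said of these compounds alone.

Compound 1 `O=C(CCCc1nc2ccccc2c(=O)[nH]1)N/N=C/c1ccc([N+](=O)[O-])cc1`: 270000000 nM
Compound 2 `O=C(CCCc1nc2ccccc2c(=O)[nH]1)N/N=C/c1ccc(O)c(O)c1`: 50000000 nM
Compound 3 `O=C(CCCc1nc2ccccc2c(=O)[nH]1)N/N=C/c1ccc(O)cc1`: 170000000 nM

The three measured compounds share one core and differ only in the aryl group on the carbon with a double bond to nitrogen. In a physicochemical assay, read by spectrophotometry, with a stated time of 6 min (a higher number here means a weaker inhibitor, a lower number a stronger inhibitor), compound 3 stands second highest of the three numbers; a 1.6-fold lower number from compound 1 to compound 3 (0.20 log units; within the scatter), whereas a 3.4-fold higher number from compound 2 to compound 3 (0.53 log units; beyond the scatter).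

Compound 4 `O=C(CCCc1nc2ccccc2c(=O)[nH]1)N/N=C/c1cc(O)c(O)c(O)c1` is not yet measured. It differs from compound 3 in one place: 3,4,5-trihydroxyphenyl in place of 4-hydroxyphenyl on a carbon with a double bond to nitrogen. The step that bears on this is the one in which hydrogen replaced hydroxy, a 3.4-fold higher number from compound 2 to compound 3 (0.53 log units; beyond the scatter); read in reverse, adding hydroxy lowered the number modestly. Since 3,4,5-trihydroxyphenyl enters, a modest lowering beyond the scatter is expected in this assay. The expected step for compound 4 is a 5.7-fold lower number from compound 3 to compound 4 (0.75 log units; beyond the scatter). Compound 4 is therefore estimated at 30000000 nM, within 10000000 nM to 100000000 nM.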

Compound 4, half-maximal inhibitory concentration: 40000000 nM
Estimate against measurement, compound 4: 1.3-fold (0.12 log units) below, and the stated range covers the measured number.
By their numbers in this assay, from the lowest: compounds 4 and 2 (each within the scatter of the next); then compounds 3 and 1 (each within the scatter of the next).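

In this assay, 3,4,5-trihydroxyphenyl on the carbon with a double bond to nitrogen lowers the number beyond the scatter against 4-hydroxyphenyl (a 4.3-fold lower number from compound 3 to compound 4 (0.63 log units; beyond the scatter)) and against 4-nitrophenyl (a 6.8-fold lower number from compound 1 to compound 4 (0.83 log units; beyond the scatter)). A third hydroxy, however, adds nothing that can be separated from the scatter (a 1.3-fold lower number from compound 2 to compound 4 (0.10 log units; within the scatter)), so among these compounds the benefit of more hydroxy groups stops growing after 3,4-dihydroxyphenyl. Nothing available here explains this flattening.

Still open, as far as these compounds go, is whether an amine, a carboxylic acid or a methoxy group on the aryl ring would match hydroxy. From the compounds shown here alone, whether a longer chain on the shared core would shift these numbers is also open.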